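The source may hold more compounds than are shown below. What is called first, only, known or untested is meant among the compounds shown, and "the series" means these compounds.

In a functional assay on U-87MG ATCC cells (Homo sapiens) for cytotoxicity, read by MTT assay, with a stated time of 72 h (a higher number here means a weaker inhibitor, a lower number a stronger inhibitor), compound 1 `CN(C)CCn1cnnc1-c1cc(Oc2ccc(NC(=O)N/N=C/c3c[nH]c4ccccc34)cc2F)ccn1` gives 690 nM, the lowest of the two numbers available in the series. The nearest measured neighbour is compound 3 `Cn1cnnc1-c1cc(Oc2ccc(NC(=O)N/N=C/c3ccccc3)cc2F)ccn1`, which in this assay gives 36300 nM. Compound 2 `Cn1ncnc1-c1cc(Oc2ccc(NC(=O)N/N=C/c3ccccc3)cc2F)ccn1` in this assay gives only > 100000 nM, which is a limit of the assay and not a number (the limit of > 100000 nM in this assay, at which 1 of the 3 values shown sits). Among the compounds with values here, the one single-point comparison so far, an at least 2.7-fold lower number from compound 2 to compound 3 (0.44 log units; beyond the scatter), concerns the triazole and says nothing about the group on the hydrazone carbon. Compound 2 and compound 3 both carry a phenyl on that carbon where compound 1 carries the indolyl, yet each also differs from compound 1 in the side chain on the triazole, so their values only show that the two phenyl compounds sit far above compound 1, without isolating either change.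

Compound 4 `COc1cc(/C=N/NC(=O)Nc2ccc(Oc3ccnc(-c4nncn4CCN(C)C)c3)c(F)c2)cc(OC)c1OC` differs from compound 1 by 3,4,5-trimethoxyphenyl in place of 1H-indol-3-yl on a carbon with a double bond to nitrogen. Within the data shown here, no measured step covers this change. The only hint is that losing the indolyl for a plain phenyl, alongside the other change, gives much higher numbers in compound 2 and compound 3. A moderate loss is therefore expected for compound 4, the step estimated as a 2.9-fold higher number from compound 1 to compound 4 (0.46 log units; beyond the scatter). Compound 4 is estimated at 2000 nM, within 400 nM to 12000 nM.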

Compound 4, half-maximal inhibitory concentration: 22500 nM
The estimate for compound 4 lay 11-fold (1.05 log units) below the measured number; the measured number lies above the stated range.
By their numbers in this assay, from the lowest: compound 1; then compounds 4 and 3 (each within the scatter of the next). At a limit, above all of these: compound 2.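

In this assay, within the data shown here, 3,4,5-trimethoxyphenyl in place of 1H-indol-3-yl on a carbon with a double bond to nitrogen gives a 33-fold higher number from compound 1 to compound 4 (1.51 log units; beyond the scatter), and with the rest of compound 1 unchanged, this is the only reading of that position on its own. The phenyl compounds, compound 2 and compound 3, changed this group only together with the side chain on the triazole, whereas this pair shows that the group on the hydrazone carbon alone carries a large part of the number, and that this substituted phenyl does not match the indolyl. The indolyl leaves with its hydrogen-bond donor and the trimethoxyphenyl brings hydrogen-bond acceptors, but nothing measured in the series ties the step to either feature.

Going by these compounds, whether the ring itself or the indole hydrogen on nitrogen matters remains open, and a 1-methyl-1H-indol-3-yl group on the same carbon would separate the two. Also open, on these data alone, is how a plain phenyl or a pyridinyl group at this position would read on the unchanged remainder of compound 1.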